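Alkyl chain in place of the chlorobenzyl on sulfur

This account rests on a few compounds, and the source may have more. Where it says the series, first, only, none or still open, it means among the compounds named here.

Measured so far in a functional assay on SMMC-7721 cells (Homo sapiens) for antiproliferative activity, read by CCK-8 assay, with a stated time of 48 h; on this read-out higher numbers stand for weaker inhibition and lower numbers for stronger inhibition:
- compound 1 `O=c1c2ccccc2[se]n1-c1nc(SCc2ccc(Cl)cc2)n[nH]1`: 33900 nM
- compound 2 `CC(C)Sc1n[nH]c(-n2[se]c3ccccc3c2=O)n1`: 6010 nM
- compound 3 `Cc1cccc(CSc2n[nH]c(-n3[se]c4ccccc4c3=O)n2)c1`: 9040 nM

Compound 1 gives the highest of the three numbers; compound 3 lies nearest to it and compound 2 furthest. Compound 4 `CCCCCSc1n[nH]c(-n2[se]c3ccccc3c2=O)n1` is not yet measured. It differs from compound 1 as follows: butyl in place of 4-chlorophenyl on a saturated chain carbon bound to a sulfur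

Going by the values given here, two measured steps bear on this change. Replacing the whole 4-chlorobenzyl by isopropyl gives a 5.6-fold lower number from compound 1 to compound 2 (0.75 log units; beyond the scatter). Replacing the 4-chlorophenyl by 3-methylphenyl gives a 3.8-fold lower number from compound 1 to compound 3 (0.57 log units; beyond the scatter). Both moves away from the 4-chlorobenzyl lowered the number beyond the scatter, and the isopropyl compound 2 and the 3-methylbenzyl compound 3 sit within the scatter of each other. A pentyl chain on sulfur is therefore expected to behave like compound 2, with a modest lowering expected, a 4.8-fold lower number from compound 1 to compound 4 (0.69 log units; beyond the scatter). In this assay compound 4 is expected to give about 7000 nM, with a range from 3000 nM to 20000 nM.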

Compound 4, half-maximal inhibitory concentration: 31400 nM
The estimate for compound 4 lay 4.5-fold (0.65 log units) below the measured number; measured number outside the range, above it.
By their numbers in this assay, from the lowest: compounds 2 and 3 (each within the scatter of the next); then compounds 4 and 1 (each within the scatter of the next).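

In this assay the alkyl groups on sulfur do not read alike: pentyl gives a 5.2-fold higher number from compound 2 to compound 4 (0.72 log units; beyond the scatter) and does not carry over the lowering seen with isopropyl. Exchanging the 4-chlorobenzyl for pentyl gives a 1.1-fold lower number from compound 1 to compound 4 (0.03 log units; within the scatter) and leaves the two within the scatter of each other. Against 3-methylbenzyl, pentyl gives a 3.5-fold higher number from compound 3 to compound 4 (0.54 log units; beyond the scatter) and so a ring on the saturated chain carbon does not by itself set the number: compound 1 and compound 3 both carry one yet stand apart, as do the ring-free compound 2 and compound 4.

Nothing available accounts for these differences.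
Going by these compounds, compound 2 and compound 4 differ in both chain length and branching, and which of the two matters stays open; an ethyl, a straight propyl or an octyl chain on sulfur would bear on it.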